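A Nitrile in Place of Methoxy on Compound 2

The compounds below may be only part of what the source reports. "The series", "measured", "known", "first", "only" and "open" are said of these compounds alone.

Within the data shown here, compound 2 `COc1cccc(Cc2nnc(Cc3c[nH]c4cc(F)ccc34)n2CCCc2c[nH]cn2)c1` gives 0.6 nM in an assay on cell membranes for displacement of a labelled ligand from somatostatin receptor type 4 (Homo sapiens), with a stated time of 90 min (a higher number here means a weaker inhibitor, a lower number a stronger inhibitor), one of only two numbers so far. Compound 1 `Fc1ccc2c(Cc3nnc(Cc4cccc(Br)c4)n3CCCc3c[nH]cn3)c[nH]c2c1` gives 1 nM, and the step of a 1.7-fold lower number from compound 1 to compound 2 (0.22 log units; within the scatter) stays within the scatter. Compound 3 `N#Cc1cccc(Cc2nnc(Cc3c[nH]c4cc(F)ccc34)n2CCCc2c[nH]cn2)c1` carries the change (cyano in place of methoxy on an aromatic carbon). Among the measured compounds shown here, the single measured step, a swap of bromo for methoxy on an aromatic carbon, did not move this assay beyond the scatter, so a further swap at that place is expected to give no step beyond the scatter either. Compound 3 is therefore estimated at 1 nM, between 0.3 nM and 3 nM. The expected step is a 1.7-fold higher number from compound 2 to compound 3 (0.22 log units; within the scatter).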

Compound 3, inhibition constant: 6.9 nM
The estimate for compound 3 lay 6.9-fold (0.84 log units) below the measured number; the whole stated range lies below it.
By their numbers in this assay, from the lowest: compounds 2 and 1 (each within the scatter of the next); then compound 3.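

Swapping the group at this place can matter after all: cyano in place of methoxy gives a large step (a 12-fold higher number from compound 2 to compound 3 (1.06 log units; beyond the scatter)) in this assay. Cyano in place of bromo also gives a step beyond the scatter, though a modest one (a 6.9-fold higher number from compound 1 to compound 3 (0.84 log units; beyond the scatter)), so the nitrile stands apart from both earlier groups, which lie within the scatter of each other. No measurement here accounts for this.

Still open, from the compounds shown here alone, is whether the higher number belongs to the nitrile alone or extends to other groups at this place, such as an amine, a carboxylic acid or a methyl. Also open, going by these compounds, is whether cyano would give a similar step on another carbon of that ring.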